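Aryl variation on the shared core: compound 3 outlook

The compounds below may be only part of what the source reports. "The series", "measured", "known", "first", "only" and "open" are said of these compounds alone.

Going by the values given here, compound 1 `Fc1ccc(-c2cn3ccnc3c(-c3ccc4ncn(C5CCCCC5)c4c3)n2)cc1` in a functional assay on RPMI-8226 cells (Homo sapiens) for inhibition, read by sulforhodamine B assay, with a stated time of 48 h, tested at 10 uM (on this read-out higher numbers stand for more inhibition at the one concentration tested (going by the name of the read-out) and lower numbers for less inhibition), gives 50.1%, the lowest of the two numbers known; compound 2 `c1csc(-c2cn3ccnc3c(-c3ccc4ncn(C5CCCCC5)c4c3)n2)c1` gives 52.3%, and the step of a number 2.2 percentage points higher from compound 1 to compound 2 (within the scatter) is within the scatter. Compound 3 `FC(F)(F)c1cccc(-c2cn3ccnc3c(-c3ccc4ncn(C5CCCCC5)c4c3)n2)c1` differs from compound 1 in one place: 3-(trifluoromethyl)phenyl in place of 4-fluorophenyl on an aromatic carbon. Among the compounds with values here, the only measured step touching this place is a number 2.2 percentage points higher from compound 1 to compound 2 (within the scatter), so no shift beyond the scatter is expected for this assay from compound 1 to compound 3, i.e. an estimated step of a number 0.1 percentage points lower from compound 1 to compound 3 (within the scatter). Compound 3 is estimated at 50% in this assay, range 35% to 65%.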

Compound 3, a percentage reported as inhibition, at one concentration (the size of the read-out at that concentration, not a potency): 32.1%
Beside the measured number, compound 3's estimate is 17.9 percentage points above it, and the stated range ends above it.
By their numbers in this assay, from the lowest: compound 3; then compounds 1 and 2 (each within the scatter of the next).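

In this assay, the change to 3-(trifluoromethyl)phenyl on this aromatic carbon gives a number 18 percentage points lower from compound 1 to compound 3 (beyond the scatter) and also a number 20.2 percentage points lower from compound 2 to compound 3 (beyond the scatter) in the same read-out. This position therefore does not treat all aryl groups alike, a difference that the swap between 4-fluorophenyl and thiophen-2-yl did not reveal. No available evidence accounts for this difference.

The compounds shown leave open whether the trifluoromethyl group itself or its placement on the phenyl ring drives the step. Going by these compounds, how an aliphatic amine or a carboxylic acid at this position would read also remains open.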